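Chloro in place of fluoro: expected solubility of compound 4

The source may hold more compounds than are shown below. What is called first, only, known or untested is meant among the compounds shown, and "the series" means these compounds.

The account starts from compound 3 `COc1ccc2nc(C)cc(OCC(=O)Nc3ccc(F)cc3)c2c1`, which in a physicochemical assay for solubility, in phosphate buffer, measured as kinetic solubility, with a stated time of 1 h, at pH 7.4 (on this read-out lower numbers stand for lower solubility and higher numbers for higher solubility), gives 104000 nM, the highest of the numbers in hand. Compound 1 `COc1ccc2nc(C)cc(OCC(=O)Nc3cc(C)cc(C)c3)c2c1` gives 26000 nM in this assay. Compound 2 `COc1ccc2nc(C)cc(OCC(=O)Nc3ccc(Br)c(C)c3)c2c1` gives < 1000 nM in this assay, and that value is a limit of the assay rather than a number (the limit of < 1000 nM in this assay, at which 1 of the 3 values shown sits). The measured steps are all on the same amide-type nitrogen: a 4.0-fold higher number from compound 1 to compound 3 (0.60 log units; beyond the scatter), an at least 100-fold higher number from compound 2 to compound 3 (2.01 log units; beyond the scatter), and an at least 26-fold lower number from compound 1 to compound 2 (1.41 log units; beyond the scatter).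

Compound 4 `COc1ccc2nc(C)cc(OCC(=O)Nc3ccc(Cl)cc3)c2c1` differs from compound 3 in one place: chloro in place of fluoro on an aromatic carbon. Among the measured compounds shown here, none of the measured steps exchanges one halogen for another at this position; each of them alters the whole substitution pattern of the ring, and the two that reach compound 3 move the number upward by modest to large amounts. A single swap of fluoro for chloro is a smaller change than any of those, so the expected step is a modest lowering of the number, possibly within the scatter. Compound 4 is therefore expected to give about 45000 nM in this assay, in the range 12000 nM to 110000 nM, which means an expected step of a 2.3-fold lower number from compound 3 to compound 4 (0.36 log units; beyond the scatter).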

Compound 4, solubility: 9000 nM
For compound 4 the middle estimate is 5.0-fold (0.70 log units) above the measured one, and the stated range ends above it.
By their numbers in this assay, from the lowest: compound 4; then compound 1; then compound 3. At a limit, below all of these: compound 2.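

In this assay, exchanging a single fluoro for chloro on an aromatic carbon, para to a large group, is enough on its own to produce a large change, which none of the earlier whole-ring changes had isolated: a 12-fold lower number from compound 3 to compound 4 (1.06 log units; beyond the scatter). The halogen at this position also decides how the 4-halophenyl compounds stand against the 3,5-dimethylphenyl compound 1: 4-fluorophenyl gives a 4.0-fold higher number from compound 1 to compound 3 (0.60 log units; beyond the scatter), whereas 4-chlorophenyl gives a 2.9-fold lower number from compound 1 to compound 4 (0.46 log units; beyond the scatter). The step of an at least 9.0-fold higher number from compound 2 to compound 4 (0.95 log units; beyond the scatter) rests on compound 2, whose value is a limit of the assay and not a number: the limit of < 1000 nM in this assay, at which 1 of the 4 values shown sits.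

The compounds shown carry only fluoro or chloro as the lone group on this ring, so it stays open how a lone bromo, a methoxy group, an amine or a carboxylic acid at this place would read in this assay. Also open, as far as these compounds go, are whether the same exchange of fluoro for chloro gives a step of this size on a ring with a further group, such as the 3-methyl of compound 2, and what lies behind the size of the step.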